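Lengthening the Amine Chain: From Propyl to Butyl

The source may hold more compounds than are shown below. What is called first, only, known or untested is meant among the compounds shown, and "the series" means these compounds.

Of the compounds shown here, two sharing one core have been measured in an assay on isolated protein for inhibition of Amine oxidase [flavin-containing] B (Homo sapiens), read by fluorescence and Amplex Red, with a stated time of 15 min, tested at 50 uM; on this read-out higher numbers stand for more inhibition at the one concentration tested (going by the name of the read-out) and lower numbers for less inhibition. Compound 1 `C#CCN(CC)Cc1cn(-c2cc(NC(=S)NCC)ncn2)cn1` carries an ethyl chain, and in this assay compound 1 gives 35.1%. Compound 2 `C#CCN(CCC)Cc1cn(-c2cc(NC(=S)NCC)ncn2)cn1` carries a propyl chain in its place, and in this assay compound 2 gives 24.3%. Going by the values given here, the single step between them, a number 10.8 percentage points lower from compound 1 to compound 2 (beyond the scatter), is modest yet larger than the usual scatter of repeated measurements. Among the compounds with values here, compound 2 therefore stands lowest of the two numbers, with compound 1 as its only neighbour and the higher of the pair.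

Compound 3 `C#CCN(CCCC)Cc1cn(-c2cc(NC(=S)NCC)ncn2)cn1` has not yet been measured. It differs from compound 2 by methyl in place of hydrogen on a saturated chain carbon, three bonds along the chain from an amine nitrogen, so the propyl becomes butyl. Within the data shown here, the only measured step that bears on this change is a number 10.8 percentage points lower from compound 1 to compound 2 (beyond the scatter), where the same kind of chain lengthening lowered inhibition. A further drop of similar or somewhat smaller size is expected, a number 8.3 percentage points lower from compound 2 to compound 3 (within the scatter). Compound 3 is therefore estimated at 16%, within a range from 4% to 30%.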

Compound 3, a percentage reported as inhibition, at one concentration (the size of the read-out at that concentration, not a potency): 20.1%
Beside the measured number, compound 3's estimate is 4.1 percentage points below it, and the stated range covers the measured number.
By their numbers in this assay, from the lowest: compounds 3 and 2 (each within the scatter of the next); then compound 1.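

Going from propyl to butyl gives a number 4.2 percentage points lower from compound 2 to compound 3 (within the scatter) in this assay, so this added methyl, three bonds along the chain from an amine nitrogen, cannot be told apart from no change at all. Taken from end to end, ethyl to butyl gives a number 15 percentage points lower from compound 1 to compound 3 (beyond the scatter) and confirms that the ethyl compound stands clear of both longer chains, whereas compound 2 and compound 3 sit together within the scatter; the first step alone could not show that the second added methyl would leave no readable mark. Nothing measured here gives a reason for this behaviour of the chain.

Still open, going by these compounds, is whether the level shared by propyl and butyl holds for a longer chain such as pentyl or hexyl, or whether it shifts again. Equally open, on these data alone, is what a methyl group in place of the ethyl would give, and whether a branched chain such as isopropyl or a ring such as cyclopropyl on the same amine nitrogen would behave like the straight chains.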